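Swapping the Sulfonyl Aryl Group in a Hydroxyamide Series

The compounds below may be only part of what the source reports. "The series", "measured", "known", "first", "only" and "open" are said of these compounds alone.

For the measured compounds named here, compound 1 `COc1cccc(S(=O)(=O)c2ccc(NC(=O)C(C)(O)C(F)(F)F)cc2)c1` is the only member of this small set with a numerical result: in a functional assay (Cavia porcellus) with sulfonylurea receptors; K-ATP channels (Homo sapiens) as the target (a lower number here means a stronger inhibitor, a higher number a weaker inhibitor), compound 1 gives 16000 nM. Compound 2 `CC(O)(C(=O)Nc1ccc(S(=O)(=O)c2cccc(C(F)(F)F)c2)cc1)C(F)(F)F` reaches only a limit of the assay, > 30000 nM in this assay. Compound 3 `CC(O)(C(=O)Nc1ccc([N+](=O)[O-])c(S(=O)(=O)c2ccccc2)c1)C(F)(F)F` likewise reaches only a limit, > 30000 nM. Going by the values given here, the step of an at least 1.8-fold higher number from compound 1 to compound 2 (0.27 log units; that floor lies within the scatter) is the one change on the sulfonyl-bound ring that has been followed with numbers. Compound 4 `CC(O)(C(=O)Nc1ccc(S(=O)(=O)c2ccc([N+](=O)[O-])cc2)cc1)C(F)(F)F` has not been measured; it differs from compound 1 by 4-nitrophenyl in place of 3-methoxyphenyl on a sulfonyl sulfur. The measured step from compound 1 to compound 2 bears on this change only loosely, since it replaces the methoxy with a different group, yet it leaves compound 2 at the limit of > 30000 nM in this assay, at which 2 of the 3 values shown sit. Compound 3, which also carries a nitro group, sits at that same limit. On this evidence the step expected for compound 4 is a 1.9-fold higher number from compound 1 to compound 4 (0.27 log units; within the scatter), toward a weaker inhibitor, most likely at or beyond the limit. The estimate for compound 4 is 30000 nM, within 12000 nM to 80000 nM.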

Compound 4, half-maximal inhibitory concentration: > 30000 nM
Compound 4: only a limit was reported; the forecaster's own chance of this, stated with the estimate: 55%; the middle value sits exactly at the limit.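

The exchange of 3-methoxyphenyl for 4-nitrophenyl on a sulfonyl sulfur gives an at least 1.8-fold higher number from compound 1 to compound 4 (0.27 log units; that floor lies within the scatter), so a second replacement at this position, now of the whole aryl group, also fails to show a stronger inhibitor than compound 1. In this assay compound 4 gives > 30000 nM, which is a limit of the assay and not a number, so the size of the change cannot be read beyond that floor, and a real difference from compound 1 remains unproven. With compound 4 added, compound 1 is the one exception to the run of limit values: the limit of > 30000 nM in this assay, at which 3 of the 4 values shown sit.

The compounds shown leave open how far compound 4 lies past the limit. They also leave open whether an amine or a carboxylic acid on this aryl ring would give a measurable number.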